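The source may hold more compounds than are shown below. What is called first, only, known or untested is meant among the compounds shown, and "the series" means these compounds.

Three ureas share one core. Compound 1 `CCOC(=O)c1cccc(NC(=O)N[C@H](C)c2ccccc2)c1` gives 94% in an ADME assay on the whole organism with Oryza sativa as the target, tested at 1 uM; on this read-out lower numbers stand for a stronger effect and higher numbers for a weaker effect at the one concentration tested. Compound 2 `COc1cccc(NC(=O)N[C@H](C)c2ccccc2)c1` gives 92% in this assay, and compound 3 `C[C@@H](NC(=O)Nc1cccc(Cl)c1)c1ccccc1` gives 91% in this assay. The steps among them were a number 2 percentage points lower from compound 1 to compound 2 (within the scatter), a number 3 percentage points lower from compound 1 to compound 3 (within the scatter) and a number 1 percentage points lower from compound 2 to compound 3 (within the scatter), so the three numbers sit together within the scatter and compound 3 cannot be set apart from the other two. Compound 4 `C[C@@H](NC(=O)Nc1cccc(I)c1)c1ccccc1` is not yet measured; it differs from compound 3 as follows: iodo in place of chloro on an aromatic carbon. The step that bears most directly on this change is a number 1 percentage points lower from compound 2 to compound 3 (within the scatter), where one substituent on the aromatic carbon was exchanged for another, and a number 3 percentage points lower from compound 1 to compound 3 (within the scatter) shows the same kind of exchange with a third group; neither exchange moved the read-out beyond the scatter. Compound 4 is therefore expected to show a number 1 percentage points lower from compound 3 to compound 4 (within the scatter), that is, no step beyond the scatter. The estimate for compound 4 in this assay is 90%, with a range from 80% to 98%.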

Compound 4, a percentage reported as activity, at one concentration (the size of the read-out at that concentration, not a potency): 75%
Estimate against measurement, compound 4: 15 percentage points above, outside the stated range (below it).
By their numbers in this assay, from the lowest: compound 4; then compounds 3, 2 and 1 (each within the scatter of the next).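

For the compounds shown here, on this aromatic carbon, iodo is the first group to stand apart in this assay, whether it replaces chloro (a number 16 percentage points lower from compound 3 to compound 4 (beyond the scatter)), methoxy (a number 17 percentage points lower from compound 2 to compound 4 (beyond the scatter)) or ethoxycarbonyl (a number 19 percentage points lower from compound 1 to compound 4 (beyond the scatter)). The exchanges among those three groups had all stayed within the scatter, so the read-out had seemed indifferent to this position, yet exchanging one single halogen atom for another, with no hydrogen-bond donors or acceptors counted on either, is enough to move it beyond the scatter. Nothing at hand accounts for the difference between iodo and chloro.

As far as these compounds go, whether bromo on the same carbon would group with chloro or with iodo remains open. So does whether an amine, a carboxylic acid or a longer chain there would leave the number with the first three compounds or with compound 4.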